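From a Dimethoxyphenyl to a Pyridyl Analogue

The source may hold more compounds than are shown below. What is called first, only, known or untested is meant among the compounds shown, and "the series" means these compounds.

Three compounds sharing a sugar-bearing ketone core were tested in an assay for inhibition of glucose-6-phosphatase catalytic subunit 1 (Rattus norvegicus), tested at 100 uM; a lower number here means less inhibition, a higher number more inhibition at the concentration tested (going by the name of the read-out). Compound 1 `O=C(/C=C/c1ccc2ccccc2c1)C[C@@H]1O[C@H](CO)[C@@H](O[C@@H]2O[C@H](CO)[C@@H](O)[C@H](O)[C@H]2O)[C@H](O)[C@H]1O` gives -3.9%. Compound 2 `CCOC(=O)C(C(=O)OCC)C(CC(=O)C[C@@H]1O[C@H](CO)[C@@H](O)[C@H](O)[C@H]1O)c1ccccc1`, carrying a phenyl group, gives -3.3%. Compound 3 `CCOC(=O)C(C(=O)OCC)C(CC(=O)C[C@@H]1O[C@H](CO)[C@@H](O)[C@H](O)[C@H]1O)c1ccc(OC)c(OC)c1` gives 36.2%, which is the highest of the three numbers; its nearest neighbour is compound 2, and compound 1 lies furthest below it, both beyond the scatter.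

Within the data shown here, the one step among the measured compounds is a number 39.5 percentage points higher from compound 2 to compound 3 (beyond the scatter), a large rise that accompanies the arrival of the two methoxy groups on the aromatic ring.

Compound 4 `CCOC(=O)C(C(=O)OCC)C(CC(=O)C[C@@H]1O[C@H](CO)[C@@H](O)[C@H](O)[C@H]1O)c1cccnc1` is the next compound to be measured in this assay. It differs from compound 3 as follows: pyridin-3-yl in place of 3,4-dimethoxyphenyl on a saturated chain carbon bound to two saturated chain carbons

The step from compound 2 to compound 3 is the only one that bears on this change. It shows that the 3,4-dimethoxyphenyl group carries the inhibition seen in compound 3, while the bare phenyl of compound 2 gives essentially none. Since compound 4 keeps neither methoxy group, the expectation is a drop in this assay, estimated as a number 28.2 percentage points lower from compound 3 to compound 4 (beyond the scatter), back toward the region of compound 2. Compound 4 is therefore expected to give about 8%, within a range from -10% to 30%.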

Compound 4, a percentage reported as inhibition, at one concentration (the size of the read-out at that concentration, not a potency): 37.6%
Compound 4: the middle estimate sits 29.6 percentage points below what was measured; the measured number lies above the stated range.
By their numbers in this assay, from the lowest: compounds 1 and 2 (each within the scatter of the next); then compounds 3 and 4 (each within the scatter of the next).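

In this assay, pyridin-3-yl in place of 3,4-dimethoxyphenyl on a saturated chain carbon bound to two saturated chain carbons gives a number 1.4 percentage points higher from compound 3 to compound 4 (within the scatter), so the two groups cannot be told apart at this place, although the smaller pyridin-3-yl carries no methoxy group. The methoxy groups are therefore not needed for this level of inhibition: with pyridin-3-yl in place of phenyl, the reading shows a number 40.9 percentage points higher from compound 2 to compound 4 (beyond the scatter), and the change from a ring of carbon only to a ring with 1 hetero atom is enough to separate the two compounds. Among these three compounds, then, compound 2 with its bare phenyl stands apart, while two quite different aromatic groups give readings within the scatter of each other, and nothing shown here says what lies behind this.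

The compounds shown leave open whether a phenyl ring with a single methoxy group, or a pyridin-4-yl ring, would read with compound 3 and compound 4 or with compound 2. They also leave open whether this picture would hold if a carboxylic acid took the place of the two ethyl esters.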